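A few compounds are considered here, and "the series" means these few. Any claim that something is new, unique, unknown or untested is made for them only; others in the source may bear on it.

Measured in a functional assay (Homo sapiens) for inhibition, using a membrane potential dye, in the presence of a further agent that is not named here; on this read-out lower numbers stand for stronger inhibition and higher numbers for weaker inhibition:
compound 1 `COc1ccc(Oc2ccc([N+](=O)[O-])cc2C(=O)Nc2ccc(F)cc2)cc1` gives 7200 nM
compound 2 `COc1ccc(NC(=O)c2cc([N+](=O)[O-])ccc2Oc2ccc(OC)cc2)cc1` gives 3400 nM

Compound 2 stands at the lower of these two numbers, that is the stronger inhibition. Among the compounds with values here, the only measured step, a 2.1-fold lower number from compound 1 to compound 2 (0.33 log units; beyond the scatter), came from methoxy in place of fluoro on an aromatic carbon. Compound 3 `COc1ccc(Oc2ccc([N+](=O)[O-])cc2C(=O)Nc2ccccc2S(N)(=O)=O)cc1` is not yet measured. It differs from compound 2 by 2-sulfamoylphenyl in place of 4-methoxyphenyl on an amide-type nitrogen. Within the data shown here, no measured step covers a change of this kind: the one step that exists is a different swap, and it was modest. There is thus no firm ground for expecting a shift in either direction, and the estimate for compound 3 in this assay stays close to the value of compound 2, with a wide margin. Compound 3 is expected to give about 5000 nM, with a likely range from 1500 nM to 15000 nM, and the expected step of a 1.5-fold higher number from compound 2 to compound 3 (0.17 log units; within the scatter) is meant to stay within the scatter.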

Compound 3, half-maximal inhibitory concentration: "no significant activity" (no number reported)
Compound 3 has no reported number here, so the estimate cannot be set against anything.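

In this assay, within the data shown here, compound 3 is reported as showing no significant activity, without a number, so no step from compound 2 to compound 3 can be read. From the compounds shown here alone, how far 2-sulfamoylphenyl in place of 4-methoxyphenyl weakens inhibition stays open. Nothing measured here offers an explanation for this result.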